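This account rests on a few compounds, and the source may have more. Where it says the series, first, only, none or still open, it means among the compounds named here.

Compound 1 `O=C(CCc1ccc(C(F)(F)F)cc1)Nc1ccc2nc(N3CC4CC3CN4)ccc2c1`: 210 nM
Compound 2 `CC1CCN(c2ccc3cc(NC(=O)CCc4ccc(C(F)(F)F)cc4)ccc3n2)C1`: 2 nM
Compound 3 `O=C(CCc1ccc(C(F)(F)F)cc1)Nc1ccc2nc(N3CCCC3)ccc2c1`: 3 nM; 3 nM (2 entries)

In an assay on isolated protein for displacement of a labelled ligand from melanin-concentrating hormone receptor 1 (Homo sapiens) (a higher number here means a weaker inhibitor, a lower number a stronger inhibitor), compound 2 gives 2 nM, the lowest of the two single numbers recorded; its nearest neighbour is compound 1, with a 110-fold lower number from compound 1 to compound 2 (2.02 log units; beyond the scatter) separating them. Compound 3 gives 3 nM; 3 nM (2 entries) in this assay, and those entries sit within the scatter of the number for compound 2, so no order between compound 2 and compound 3 can be claimed.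

The step under consideration leads to compound 4 `NC1CCN(c2ccc3cc(NC(=O)CCc4ccc(C(F)(F)F)cc4)ccc3n2)C1`, which has not yet been measured in this assay. Its difference from compound 2 is amino in place of methyl on a saturated ring carbon. Among the compounds with values here, no measured step exchanges a methyl for an amino group, so nothing bears on this change directly. Within the data shown here, the only measured step, from compound 1 to compound 2, replaced a group with a second nitrogen by one without, and it was large; compound 3, which lacks the methyl altogether, shows a number close to that of compound 2. On that basis compound 4 is expected to give a somewhat higher number, with a 7.5-fold higher number from compound 2 to compound 4 (0.88 log units; beyond the scatter) as the estimated step. The estimate for compound 4 is 15 nM, within a range from 3 nM to 80 nM.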

Compound 4, half-maximal inhibitory concentration: 12 nM
Compound 4: the middle estimate sits 1.3-fold (0.10 log units) above what was measured, and the stated range covers the measured number.
By their numbers in this assay, from the lowest: compound 2; then compound 4; then compound 1.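

In this assay, within the data shown here, the saturated ring carbon two ring bonds from the ring nitrogen does not treat these two groups alike: amino in place of methyl gives a 6.0-fold higher number from compound 2 to compound 4 (0.78 log units; beyond the scatter) and this modest step is the first measured change at that carbon. Compound 4 carries a second nitrogen in its group just as compound 1 does, yet there is an 18-fold lower number from compound 1 to compound 4 (1.24 log units; beyond the scatter) and so a second nitrogen alone does not set the number of compound 1, a point the earlier step could not settle because that step removed the nitrogen and changed the ring system at once. No measurement at hand bears on why either step has the size it has.

As far as these compounds go, whether a hydroxyl group, a dimethylamino group or an aminomethyl group on the same ring carbon would give a number closer to that of compound 2 or to that of compound 4 remains open. The compounds shown also leave open whether the two mirror-image forms of compound 4 differ, and whether the step seen here would hold in a six-membered piperidine ring.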